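Isopropylpyrazole replacing an aminomethyl-oxazole on a shared core

This account rests on a few compounds, and the source may have more. Where it says the series, first, only, none or still open, it means among the compounds named here.

The series shares one core carrying an ethylcarbamoyl group and a resorcinol bearing an isopropyl group, and varies the five-membered ring beside them. Compound 1 `CCNC(=O)c1noc(-c2cc(C(C)C)c(O)cc2O)c1-c1cc(CO)no1` carries a hydroxymethyl-substituted ring; in a functional assay on A2780 cells (Homo sapiens) for inhibition (a lower number here means a stronger inhibitor, a higher number a weaker inhibitor), compound 1 gives 5 nM. Compound 3 `CCNC(=O)c1noc(-c2cc(C(C)C)c(O)cc2O)c1-c1cc(C(N)=O)no1` differs by carbamoyl in place of hydroxymethyl on an aromatic carbon, and compound 3 gives 15 nM. That single step is a 3.0-fold higher number from compound 1 to compound 3 (0.48 log units; beyond the scatter). Compound 2 `CCCNCc1cc(-c2c(C(=O)NCC)noc2-c2cc(C(C)C)c(O)cc2O)on1` carries the 3-((propylamino)methyl)-1,2-oxazol-5-yl group, but in this assay compound 2 gives "not determined" (no result reported), so it stands nowhere on the numbers shown. Compound 4 `CCNC(=O)c1noc(-c2cc(C(C)C)c(O)cc2O)c1-c1ccn(C(C)C)n1` follows from compound 2 by the change (1-isopropyl-1H-pyrazol-3-yl in place of 3-((propylamino)methyl)-1,2-oxazol-5-yl on an aromatic carbon). Within the data shown here, no measured step bears directly on this exchange: the one known step changes a substituent on the same kind of ring rather than the ring itself, and its modest size only suggests that the scatter of this position is limited. The expectation for compound 4 therefore rests on the range spanned by compound 1 and compound 3, with a wider band to allow for the exchange of the whole ring. Compound 4 is estimated at 20 nM, expected between 4 nM and 100 nM.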

Compound 4, half-maximal inhibitory concentration: 45 nM
Beside the measured number, compound 4's estimate is 2.3-fold (0.35 log units) below it, and the stated range covers the measured number.
By their numbers in this assay, from the lowest: compound 1; then compound 3; then compound 4.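

Among these compounds, compound 4 is the first compound here in which the whole group on this aromatic carbon changes, not just a substituent on the 1,2-oxazole, and in this assay the exchange carries a measurable cost. Placing 1-isopropyl-1H-pyrazol-3-yl on this carbon gives a 3.0-fold higher number from compound 3 to compound 4 (0.48 log units; beyond the scatter) and, against the hydroxymethyl compound, a 9.0-fold higher number from compound 1 to compound 4 (0.95 log units; beyond the scatter), so compound 4 has the highest number of the three measured compounds, while the larger step shows that this position responds to the group it carries beyond the one substituent change seen earlier. The direct step from compound 2 to compound 4 cannot be read, and no measurement shown gives a reason for the rise.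

The compounds shown leave open whether the higher number of compound 4 follows from the change of ring itself or from its isopropyl group, since no 1H-pyrazol-3-yl ring carrying a hydroxymethyl group, a carbamoyl group or a methyl group stands beside it. They also leave open how an amine on the 1,2-oxazole ring compares, such as the propylaminomethyl chain of compound 2, which has no number in this assay.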